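A few compounds are considered here, and "the series" means these few. Any claim that something is new, unique, unknown or untested is made for them only; others in the source may bear on it.

Of the compounds shown here, two have so far been measured in a functional assay on HCT-116 cells (Homo sapiens) for cytotoxicity, read by MTT assay, with a stated time of 2 days, tested at 10 uM; on this read-out lower numbers stand for less inhibition and higher numbers for more inhibition at the one concentration tested (going by the name of the read-out). Compound 1 `CCCCCNc1nc(NCc2ccco2)c2cc(F)ccc2n1` gives 94.2% in this assay. Compound 2 `Cc1cccc(N2CCN(CCCCNc3nc(NCc4ccco4)c4cc(F)ccc4n3)CC2)c1C` gives 97.4% in this assay, the higher of the two numbers, though its gap to compound 1 lies within the usual scatter, so the two cannot be ordered with confidence.

Compound 3 `Cc1cccc(N2CCN(CCCCNc3nc(NCc4ccco4)c4ccccc4n3)CC2)c1C` has not yet been measured. It differs from compound 2 by hydrogen in place of fluoro on an aromatic carbon, the change sitting on an aromatic carbon of a six-membered aromatic ring of carbon only, part of the fused system of two rings. Among the compounds with values here, no step between measured compounds shows this change, so the data give no direct guide to its effect. Since compound 2 already reaches 97.4%, close to the top of the read-out, only a small step, a number 4.4 percentage points lower from compound 2 to compound 3 (within the scatter), is expected, staying within the scatter. Compound 3 is therefore estimated at 93%, with a range from 80% to 99%.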

Compound 3, a percentage reported as inhibition, at one concentration (the size of the read-out at that concentration, not a potency): 94.3%
The estimate for compound 3 lay 1.3 percentage points below the measured number; the range from low to high includes it.
By their numbers in this assay, from the lowest: compounds 1, 3 and 2 (each within the scatter of the next).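

With the rest of the structure unchanged, this assay gives a number 3.1 percentage points lower from compound 2 to compound 3 (within the scatter) for hydrogen in place of fluoro on an aromatic carbon. Within the data shown here, this is the first direct reading of this change at this place, meta to a fused ring and para to a fused ring. The fluoro is therefore not shown to be needed for the read-out here, as compound 2 and compound 3 cannot be told apart, and no measurement shown explains this result.

The compounds shown leave open whether a different group at this place, such as chloro, methoxy or an amine, would give a different number. From the compounds shown here alone, with both compounds close to the top of the read-out at the one concentration tested, it also remains open whether this change would matter where inhibition is less complete.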